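Aryl change from compound 3 to compound 4

A few compounds are considered here, and "the series" means these few. Any claim that something is new, unique, unknown or untested is made for them only; others in the source may bear on it.

Values so far in a functional assay on HepG2 cells (Homo sapiens) for antiproliferative activity, read by MTT assay, with a stated time of 48 h; a higher number here means a weaker inhibitor, a lower number a stronger inhibitor (read as the half-maximal inhibitory concentration)
- compound 1 `O=C(Nc1ccc(Cl)cc1)Nc1cccc(CNc2nccnc2Cl)c1` gives 8350 nM
- compound 2 `CN(C)c1ccc(NC(=O)Nc2cccc(CNc3nccnc3Cl)c2)cc1` gives > 40000 nM (a limit, not a number)
- compound 3 `Cc1ccccc1NC(=O)Nc1cccc(CNc2nccnc2Cl)c1` gives 15300 nM

Compound 3 has one numeric neighbour, and the gap to it lies within the scatter. That gap is a 1.8-fold higher number from compound 1 to compound 3 (0.26 log units; within the scatter) and it is the closest guide here. Compound 2 stands at a limit, as the limit of > 40000 nM in this assay, at which 1 of the 3 values shown sits, records.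

Compound 4 `O=C(Nc1cccc(CNc2nccnc2Cl)c1)Nc1ccc(Cl)cc1Br` carries 2-bromo-4-chlorophenyl in place of 2-methylphenyl on an amide-type nitrogen being the full difference.

The 4-(dimethylamino)phenyl group does not recur in compound 4, so an at least 4.7-fold higher number from compound 1 to compound 2 (0.68 log units; beyond the scatter) and an at least 2.6-fold lower number from compound 2 to compound 3 (0.41 log units; beyond the scatter) bear on it less, and both rest on a limit. Compound 1 at 8350 nM carries the 4-chlorophenyl group, so a slight lean to a lower number is expected, but no step beyond the scatter. The expected change is a 1.5-fold lower number from compound 3 to compound 4 (0.18 log units; within the scatter) in this reading. Compound 4 is estimated at 10000 nM with an expected range from 4000 nM to 25000 nM in this assay.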

Compound 4, half-maximal inhibitory concentration: 6720 nM
Compound 4: the middle estimate sits 1.5-fold (0.17 log units) above what was measured; low and high end bracket the measured number.
By their numbers in this assay, from the lowest: compounds 4, 1 and 3 (each within the scatter of the next, the first and the last beyond it). At a limit, above all of these: compound 2.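

In this assay, a change of the aryl group on an amide-type nitrogen now gives a numeric step beyond the scatter, with 2-bromo-4-chlorophenyl in place of 2-methylphenyl (a 2.3-fold lower number from compound 3 to compound 4 (0.36 log units; beyond the scatter)), whereas the earlier numeric pair, compound 1 and compound 3, lay within it. Bromo in place of hydrogen on the 4-chlorophenyl group gives no readable difference (a 1.2-fold lower number from compound 1 to compound 4 (0.09 log units; within the scatter)), so compound 1 and compound 4 stand level and both lie clear of compound 3 only in the case of compound 4. Compound 2 is held at a limit, so its step to the bromo compound (an at least 5.9-fold lower number from compound 2 to compound 4 (0.77 log units; beyond the scatter)) is a bound and not a size: the limit of > 40000 nM in this assay, at which 1 of the 4 values shown sits.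

Still open, from the compounds shown here alone, is how trifluoromethyl or methoxy would read in place of chloro on this aryl group. Also open, going by these compounds, is whether a morpholine or another amine would follow the dimethylamino group of compound 2.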